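Mouse liver microsome clearance across three ring variants

The source may hold more compounds than are shown below. What is called first, only, known or untested is meant among the compounds shown, and "the series" means these compounds.

Measured so far:
compound 1 `COc1ccn2c(Nc3cc(F)cc(F)c3)c(-c3ccccn3)nc2c1`: 62 uL/min
compound 2 `COc1ccn2c(Nc3ccc(F)cn3)c(-c3ccccn3)nc2c1`: 81 uL/min

In an ADME assay on microsomes from liver (Mus musculus) for metabolic stability, read by LC-MS, using NADPH, with a stated time of 60 min, tested at 1 uM, in the presence of a further agent that is not named here (a higher number here means faster removal of the compound, a lower number slower removal), compound 1 gives 62 uL/min and compound 2 gives 81 uL/min; the step of a 1.3-fold higher number from compound 1 to compound 2 (0.12 log units; within the scatter) leaves the two within the scatter of each other, so compound 2 stands level with compound 1 on the numbers shown. Compound 3 `COc1ccn2c(Nc3ccc(F)cc3)c(-c3ccccn3)nc2c1` differs from compound 2 by 4-fluorophenyl in place of 5-fluoropyridin-2-yl on a nitrogen on an aromatic ring. Among the compounds with values here, the only measured step, a 1.3-fold higher number from compound 1 to compound 2 (0.12 log units; within the scatter), also exchanges the ring on that nitrogen and stayed within the scatter, so a step within the scatter is expected in this assay, a 1.2-fold lower number from compound 2 to compound 3 (0.10 log units; within the scatter). Compound 3 is estimated at 65 uL/min, with a range from 32 uL/min to 130 uL/min.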

Compound 3, intrinsic clearance in a liver preparation (reported as CLH), per the amount of preparation that the assay uses: 117 uL/min
Compound 3: the middle estimate sits 1.8-fold (0.26 log units) below what was measured; the measured number falls inside the stated range.
By their numbers in this assay, from the lowest: compounds 1, 2 and 3 (each within the scatter of the next).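

In this assay, two further exchanges of the ring on that nitrogen also stay within the scatter: a 1.4-fold higher number from compound 2 to compound 3 (0.16 log units; within the scatter) and a 1.9-fold higher number from compound 1 to compound 3 (0.28 log units; within the scatter). 4-Fluorophenyl, 5-fluoropyridin-2-yl and 3,5-difluorophenyl are therefore not told apart at this position, with or without a nitrogen in the ring, and even the two carbon-only rings, which differ in their fluorines, remain level. No measurement bears on why these values fall as they do.

Still open, from the compounds shown here alone, is whether a non-aromatic amine such as morpholine, or a phenyl ring carrying a carboxylic acid, would give a step beyond the scatter at this position in this assay. The compounds shown also say nothing about changes elsewhere on the shared core.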